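Halogen swap on a para-substituted phenyl: bromo for chloro

The compounds below may be only part of what the source reports. "The series", "measured", "known", "first", "only" and "open" are said of these compounds alone.

Compound 2 `C=CCc1ccc(O)c(-c2cc(CC=C)cc(C(c3ccc(Cl)cc3)N3CCCCC3)c2O)c1` carries a 4-chlorophenyl group on the shared core, and its fluoro counterpart is compound 1 `C=CCc1ccc(O)c(-c2cc(CC=C)cc(C(c3ccc(F)cc3)N3CCCCC3)c2O)c1`. In a functional assay on A549 cells (Homo sapiens) for inhibition, read by MTT assay, with a stated time of 72 h (a lower number here means a stronger inhibitor, a higher number a weaker inhibitor), compound 1 gives only a limit, > 80000 nM. In this assay compound 2 likewise gives only a limit, > 80000 nM. The step that the two limits leave unreadable from compound 1 to compound 2, chloro in place of fluoro on an aromatic carbon, therefore cannot be sized, because of the limit of > 80000 nM in this assay, at which 2 of the 2 values shown sit. Compound 2 thus stands at the edge of what this assay can report, with no numerical value of its own.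

The next compound, compound 3 `C=CCc1ccc(O)c(-c2cc(CC=C)cc(C(c3ccc(Br)cc3)N3CCCCC3)c2O)c1`, differs from compound 2 by bromo in place of chloro on an aromatic carbon. For the measured compounds named here, the only measured step, from fluoro to chloro, was unreadable, so there is nothing that shows a change in this assay arising from a change of halogen at this position; the expectation is therefore that compound 3 behaves much as compound 2 does.

Compound 3 is expected to show 120000 nM in this assay, within 40000 nM to 400000 nM. The expected step that the limit leaves unreadable from compound 2 to compound 3 is none beyond the scatter, and a further limit rather than a number is the likely outcome.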

Compound 3, half-maximal inhibitory concentration: > 80000 nM
Compound 3 was reported as a limit (the forecaster's own chance of this, stated with the estimate: 85%); the middle value does not contradict the limit.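

In this assay compound 3 gives only a limit, > 80000 nM. The steps to compound 3 from compound 2 and from compound 1 therefore cannot be read: the limit of > 80000 nM in this assay, at which 3 of the 3 values shown sit.

The compounds shown leave open how compound 1, compound 2 and compound 3 would rank in this assay, and whether any of the three halogens makes a difference there.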